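Cyclohexyl for Difluorophenyl on the Amine Nitrogen

The source may report more compounds than this note shows. Statements on the series, on what has been measured and on what is new or still open speak of the compounds shown alone.

Compound 2 `Cc1ccc(S(=O)(=O)/N=C(/CCNC2=CC(=O)c3ccccc3C2=O)Nc2ccc(F)c(F)c2)cc1` gives 55200 nM in an ADME assay on HEK293 cells (Homo sapiens) for cytotoxicity, read by MTT assay, with a stated time of 48 h (on this read-out lower numbers stand for stronger inhibition and higher numbers for weaker inhibition), which places it second highest of the three numbers measured in this series. Compound 1 `Cc1ccc(S(=O)(=O)/N=C(/CCNC2=CC(=O)c3ccccc3C2=O)Nc2ccc(F)cc2)cc1` gives 55100 nM in this assay, and compound 3 `Cc1ccc(S(=O)(=O)/N=C(/CCNC2=CC(=O)c3ccccc3C2=O)Nc2cc(F)c(F)c(F)c2)cc1` gives 82600 nM. The measured steps are small: a 1.0-fold higher number from compound 1 to compound 2 (0.00 log units; within the scatter), a 1.5-fold higher number from compound 1 to compound 3 (0.18 log units; within the scatter) and a 1.5-fold higher number from compound 2 to compound 3 (0.18 log units; within the scatter), each within the scatter, so the three compounds are not ordered by these numbers.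

Compound 4 `Cc1ccc(S(=O)(=O)/N=C(/CCNC2=CC(=O)c3ccccc3C2=O)NC2CCCCC2)cc1` carries the change (cyclohexyl in place of 3,4-difluorophenyl on an amine nitrogen). Among the compounds with values here, none of the measured steps covers a change of this kind; all three exchange hydrogen for fluoro on the aromatic ring that is now removed, and none replaces the ring itself. They bear on the step only in showing that substitution on that ring left the read-out unmoved within the scatter. Within the data shown here, with no measured step of the same kind, no direction can be drawn, and the expectation is a step in this assay that stays within the scatter, with a wide range to reflect the missing comparison. Expected, then, is a 1.0-fold lower number from compound 2 to compound 4 (0.00 log units; within the scatter). Compound 4 is estimated at 55000 nM, with a range from 22000 nM to 140000 nM.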

Compound 4, half-maximal inhibitory concentration: 50100 nM
Compound 4: middle estimate off by 1.1-fold (0.04 log units), on the high side; low and high end bracket the measured number.
By their numbers in this assay, from the lowest: compounds 4, 1, 2 and 3 (each within the scatter of the next).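

Cytotoxicity notes, amine nitrogen position: In this assay the earlier compounds varied only the fluoro pattern on the aromatic ring, whereas compound 4 replaces that ring with a non-aromatic one, and the result is still a step within the scatter (a 1.1-fold lower number from compound 2 to compound 4 (0.04 log units; within the scatter)). The comparisons with the other two aryl groups read the same way (a 1.6-fold lower number from compound 3 to compound 4 (0.22 log units; within the scatter); a 1.1-fold lower number from compound 1 to compound 4 (0.04 log units; within the scatter)), so across compounds 1 to 4 this read-out does not separate cyclohexyl from the fluorinated phenyl groups at this position. No supporting data are available to explain this absence of separation.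

Going by these compounds, all four groups at this position are six-membered carbon rings without hydrogen-bond donors or acceptors, so it remains open whether a piperidine, a carboxylic acid on the ring or a straight hexyl chain would give a step beyond the scatter. On these data alone, it is also open whether the read-out responds to a change elsewhere on the shared core, such as replacing the methyl group on the sulfonyl-bearing ring with a methoxy group or an amine.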